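The source may report more compounds than this note shows. Statements on the series, on what has been measured and on what is new or still open speak of the compounds shown alone.

Compound 1, `CNC(=O)c1cccc(S(=O)(=O)Oc2ccc(-c3cncn3C3CCN(C(=O)c4ccc(Cl)c(C(F)(F)F)c4)CC3)cc2)c1`, gives 112 nM in an assay on HEK293 cells for antagonist activity at P2X purinoceptor 7 (Homo sapiens), read by fluorescence, with a stated time of 2 h; a higher number here means a weaker inhibitor, a lower number a stronger inhibitor.
Compound 2, `CNC(=O)c1cccc(S(=O)(=O)Oc2ccc(-c3cncn3C3CCN(C(=O)c4ccc(S(C)(=O)=O)cc4)CC3)cc2)c1`, gives 202 nM in this assay.
Compound 3, `O=C(c1ccc(Cl)c(C(F)(F)F)c1)N1CCC(c2nc3cc(OS(=O)(=O)c4cccc5cnccc45)ccc3[nH]2)CC1`, gives 31 nM in this assay.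

Compounds 1 and 2 share one core and differ in a single place:

4-(methylsulfonyl)phenyl in place of 4-chloro-3-(trifluoromethyl)phenyl on a carbonyl carbon

That change produced a 1.8-fold higher number from compound 1 to compound 2 (0.26 log units; within the scatter). Compound 3 rests on a different core; the difference between its core and the core of compound 1 is not broken down here, and it sits at the lowest number of the three. Compound 4, `CS(=O)(=O)c1ccc(C(=O)N2CCC(c3nc4cc(OS(=O)(=O)c5cccc6cnccc56)ccc4[nH]3)CC2)cc1`, has not yet been measured in this assay. It carries the same change on the core of compound 3:

4-(methylsulfonyl)phenyl in place of 4-chloro-3-(trifluoromethyl)phenyl on a carbonyl carbon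

Compound 4 is estimated at 55 nM, with a likely span from 20 nM to 160 nM. The expected step from compound 3 is a 1.8-fold higher number from compound 3 to compound 4 (0.25 log units; within the scatter), because the matching step a 1.8-fold higher number from compound 1 to compound 2 (0.26 log units; within the scatter) stayed within the scatter, so a shift of similar size is anticipated rather than a large loss.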

Compound 4, half-maximal inhibitory concentration: 7 nM
For compound 4 the middle estimate is 7.9-fold (0.90 log units) above the measured one; the whole stated range lies above it.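

In this assay, the change on the core of compound 3 gave a 4.4-fold lower number from compound 3 to compound 4 (0.65 log units; beyond the scatter), so it did not behave as it had on the core of compound 1: the same change on two cores in this assay, a 1.8-fold higher number (0.26 log units; within the scatter) from compound 1 to compound 2 and a 4.4-fold lower number (0.65 log units; beyond the scatter) from compound 3 to compound 4, 8.0-fold (0.90 log units) apart, beyond the scatter of two such steps In these two pairs, then, the outcome of this change depends on the core, and the step on one core was no guide to its direction on the other. The two pairs do not show which part of the cores is responsible, nor how the change would behave on any third core.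

The compounds shown leave open whether other groups on the carbonyl carbon would follow the same split between the two cores. A phenyl carrying a carboxylic acid or an amine in place of the methylsulfonyl group would be one such case.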